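A few compounds are considered here, and "the series" means these few. Any claim that something is new, unique, unknown or untested is made for them only; others in the source may bear on it.

Compound 1 `O=C1O[C@@H](CO)CN1c1ccc(-n2cc(-c3ccccn3)cn2)c(F)c1` stands at a limit in an ADME assay on HEK293-A cells (Homo sapiens) for cytotoxicity, read by MTT assay, with a stated time of 48 h; on this read-out lower numbers stand for stronger inhibition and higher numbers for weaker inhibition: compound 1 gives > 400 ug/mL, a limit of the assay rather than a number. Compound 3 `O=C1O[C@@H](CN2CCC(O)CC2)CN1c1ccc(-n2cc(-c3ccccn3)cn2)c(F)c1` likewise returns only a limit, > 400 ug/mL. For the measured compounds named here, compound 2 `CN1CCN(C[C@H]2CN(c3ccc(-n4cc(-c5ccccn5)cn4)c(F)c3)C(=O)O2)CC1` gives 70 ug/mL, the single number in the set. Two steps are readable, an at least 5.7-fold lower number from compound 1 to compound 2 (0.75 log units; beyond the scatter) and an at least 5.7-fold higher number from compound 2 to compound 3 (0.75 log units; beyond the scatter), while a step that the two limits leave unreadable from compound 1 to compound 3. Two of the three values sit at the limit of > 400 ug/mL in this assay, at which 2 of the 3 values shown sit; only compound 2 falls away from it. Compound 4 `O=C1CCC(=O)N1C[C@H]1CN(c2ccc(-n3cc(-c4ccccn4)cn3)c(F)c2)C(=O)O1` differs from compound 1 by 2,5-dioxopyrrolidin-1-yl in place of hydroxy on a saturated chain carbon bound to a saturated ring carbon. Going by the values given here, no measured step carries this group, and the one departure from the limit belongs to compound 2 alone. With both neutral neighbours at the limit, no step beyond the scatter is expected: a number no higher from compound 1 to compound 4 (the limit leaves the size open). Compound 4 is therefore estimated at 400 ug/mL, between 150 ug/mL and 1000 ug/mL.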

Compound 4, half-maximal inhibitory concentration: > 400 ug/mL
Compound 4: a limit, no number; the forecaster's own chance of this, stated with the estimate: 65%; the middle value sits exactly at the limit.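

In this assay compound 4 gives > 400 ug/mL, a limit and not a number. On a saturated chain carbon bound to a saturated ring carbon, 2,5-dioxopyrrolidin-1-yl thus joins hydroxy and 4-hydroxypiperidin-1-yl at the limit, so the steps among these three cannot be read, and the one readable step is an at least 5.7-fold higher number from compound 2 to compound 4 (0.75 log units; beyond the scatter). Only 4-methylpiperazin-1-yl has left the limit so far: the limit of > 400 ug/mL in this assay, at which 3 of the 4 values shown sit.

On these data alone, it remains open whether morpholin-4-yl, piperazin-1-yl without the methyl, or a carboxylic acid on that carbon would leave the limit as compound 2 does.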